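Aryl ether swap to tert-butylphenyl: solubility outlook

The source may report more compounds than this note shows. Statements on the series, on what has been measured and on what is new or still open speak of the compounds shown alone.

Of the compounds shown here, three have been measured: compound 1 `COc1cccc(Oc2ccc3c(NCCCNCc4cc(F)ccc4OC)ccnc3c2)c1`, compound 2 `COc1cccc(Oc2ccc3c(NCCCNCc4cccc(OC)c4O)ccnc3c2)c1` and compound 3 `COc1ccc(F)cc1CNCCCNc1ccnc2cc(Oc3ccc(F)cc3)ccc12`. In a physicochemical assay for solubility, with a stated time of 18 h, at pH 7.4 (a lower number here means a less soluble compound, a higher number a more soluble compound), compound 1 gives 14500 nM, compound 2 gives 14500 nM and compound 3 gives 14500 nM. Compound 2 thus stands level with both companions at the digits shown: no change at the digits printed from compound 1 to compound 2 (within the scatter), and no change at the digits printed from compound 1 to compound 3 (within the scatter).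

The next compound, compound 4 `COc1cccc(CNCCCNc2ccnc3cc(Oc4ccc(C(C)(C)C)cc4)ccc23)c1O`, differs from compound 2 at the aryl ether: 4-(tert-butyl)phenyl in place of 3-methoxyphenyl on an oxygen on an aromatic ring. Among the compounds with values here, the only measured step at this position is that from compound 1 to compound 3, which stayed within the scatter. The entering group, however, is larger than the one tried there and carries no hydrogen-bond acceptor, so the earlier step is only a partial guide. On balance a modest downward step is expected in this assay, a 2.1-fold lower number from compound 2 to compound 4 (0.32 log units; beyond the scatter), with the possibility of no change beyond the scatter kept open. Compound 4 is therefore estimated at 7000 nM, with a range from 2500 nM to 20000 nM.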

Compound 4, solubility: 14500 nM
Beside the measured number, compound 4's estimate is 2.1-fold (0.32 log units) below it; the range from low to high includes it.
By their numbers in this assay, from the lowest: compounds 1, 2, 3 and 4 (each within the scatter of the next).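

Working notes: the aryl ether position tolerates more change than the earlier compounds showed, as replacing 3-methoxyphenyl with the larger, all-carbon 4-(tert-butyl)phenyl, which has no hydrogen-bond acceptor, gives in this assay no change at the digits printed from compound 2 to compound 4 (within the scatter). With no change at the digits printed from compound 1 to compound 3 (within the scatter), there are now two different replacements on this oxygen on an aromatic ring, on two different side chains, and neither step leaves the scatter. No supporting data bear on this result, so it remains an observation without an explanation.

Still open, on these data alone, is whether an amine or a carboxylic acid in place of the tert-butyl group would shift the number in this assay. A longer chain between the two amine nitrogens is also untested in the compounds shown, so the reach of this flat result beyond the aryl ether remains undefined.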